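Bromo to Methyl on the Pendant Phenyl Ring

The compounds below may be only part of what the source reports. "The series", "measured", "known", "first", "only" and "open" are said of these compounds alone.

Compound 1 `Cc1nnc(SCC(=O)N/N=c2/scc(-c3ccccc3)n2-c2ccccc2)s1`: > 200 ug/mL
Compound 2 `Cc1nnc(SCC(=O)N/N=c2/scc(-c3ccc(Br)cc3)n2-c2ccccc2)s1`: "not determined" (no result reported)
Compound 3 `Cc1ccc(-c2cs/c(=N/NC(=O)CSc3nnc(C)s3)n2-c2ccccc2)cc1`: not yet measured

For compound 1 in a functional assay on C6 cells (Rattus norvegicus) for cytotoxicity, read by MTT assay, with a stated time of 24 h (a lower number here means a stronger inhibitor, a higher number a weaker inhibitor), the value is only a limit of the assay, (the limit of > 200 ug/mL in this assay, at which 1 of the 2 values shown sits). For the measured compounds named here, compound 2 stands without any number in this assay, as its entry reads "not determined" (no result reported), so no measured step leads out of it. Compound 3 differs from compound 2 by methyl in place of bromo on an aromatic carbon. Going by the values given here, with no measured step in this assay to rest on, a change of no more than the usual scatter is expected, in no particular direction. Compound 3 is therefore estimated at 200 ug/mL, in the range 60 ug/mL to 400 ug/mL.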

Compound 3, half-maximal inhibitory concentration: 25.3 ug/mL
Compound 3: the middle estimate sits 7.9-fold (0.90 log units) above what was measured, outside the stated range (below it).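

Methyl in place of hydrogen on this aromatic carbon gives an at least 7.9-fold lower number from compound 1 to compound 3 (0.89 log units; beyond the scatter) in this assay, so this position para to a large group can shift the read-out beyond the scatter. On these data alone, the true size of that step stays unknown, since the value of compound 1 is only a limit of the assay: the limit of > 200 ug/mL in this assay, at which 1 of the 3 values shown sits. Compound 2 has no result, so the steps leading to it or from it cannot be read.

As far as these compounds go, what an ethyl group, a methoxy group or an amine would give at this position remains open.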